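Chloro to Trifluoromethyl on Two Different Cores

This account rests on a few compounds, and the source may have more. Where it says the series, first, only, none or still open, it means among the compounds named here.

Three compounds have been measured in a functional assay on MCF7 cells (Homo sapiens) for antiproliferative activity, read by sulforhodamine B assay, with a stated time of 48 h; a higher number here means a weaker inhibitor of growth, a lower number a stronger inhibitor of growth:
Compound 1 `Clc1ccc2c(NCCCN3CCN(c4ccccc4)CC3)ccnc2c1` gives 12800 nM.
Compound 2 `O=C1C(=O)N(CCCNc2ccnc3cc(Cl)ccc23)c2ccccc21` gives 23500 nM.
Compound 3 `FC(F)(F)c1ccc2c(NCCCN3CCN(c4ccccc4)CC3)ccnc2c1` gives 8750 nM.

From compound 1 to compound 3 the change is trifluoromethyl in place of chloro on an aromatic carbon, and it made a 1.5-fold lower number from compound 1 to compound 3 (0.17 log units; within the scatter). Compound 2 carries a different core; the difference between the two cores is not broken down here. Compound 4 `O=C1C(=O)N(CCCNc2ccnc3cc(C(F)(F)F)ccc23)c2ccccc21` is not yet measured. It differs from compound 2 by trifluoromethyl in place of chloro on an aromatic carbon, the same change as that between compound 1 and compound 3, at the same kind of position. A step of similar size is expected because the same change gave a 1.5-fold lower number from compound 1 to compound 3 (0.17 log units; within the scatter), so from compound 2 to compound 4 the expected step is a 1.5-fold lower number from compound 2 to compound 4 (0.17 log units; within the scatter). Compound 4 is therefore estimated at 16000 nM in this assay, most likely between 7000 nM and 40000 nM.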

Compound 4, concentration for 50% growth inhibition: 45300 nM
Compound 4: the middle estimate sits 2.8-fold (0.45 log units) below what was measured; the whole stated range lies below it.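

In this assay, trifluoromethyl in place of chloro on an aromatic carbon gave a 1.9-fold higher number from compound 2 to compound 4 (0.29 log units; within the scatter). Each step taken alone stays within the scatter, yet the two do not agree, and the step seen on one core did not carry over to the other at the same size: the same change on two cores in this assay, a 1.5-fold lower number (0.17 log units; within the scatter) from compound 1 to compound 3 and a 1.9-fold higher number (0.29 log units; within the scatter) from compound 2 to compound 4, 2.8-fold (0.45 log units) apart, beyond the scatter of two such steps. Going by these compounds alone, with only one pair on each core, this shows that a step from one core cannot simply be applied to the other, but it does not show why the two steps differ.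

The compounds shown leave open how a nitrile or an amine in that place would behave on either core. They also leave open whether a longer chain would alter the size of the step.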